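The compounds below may be only part of what the source reports. "The series", "measured", "known", "first", "only" and "open" are said of these compounds alone.

Working notes on the series. Three compounds have been run in a functional assay on Hep 3B2 cells (Homo sapiens) for cytotoxicity, read by MTT assay (a higher number here means a weaker inhibitor, a lower number a stronger inhibitor), so far. Compound 1 `COc1ccc([C@H]2Oc3cc(OC)c(OC)cc3[C@@H]2C)cc1O` gives in this assay > 19.4 ug/mL, and that figure is a limit of the assay rather than a number. Compound 2 `COC1=CC(=O)C2(C(C)C(O)c3ccc(OC)c(O)c3)OC2C1=O` gives in this assay 2.08 ug/mL. Compound 3 `COc1ccc(-c2oc3cc(OC)c(O)cc3c2C)cc1O` is recorded in this assay as "not active" (no number reported), with no number attached. Compound 1 thus stands at the limit of > 19.4 ug/mL in this assay, at which 1 of the 3 values shown sits, so its position among the measured compounds is known only as a boundary, and compound 2 is the only one of the three with a single number. Within the data shown here, no two of the measured compounds differ in one place, so no measured step exists in this assay and no direction can be read from the data.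

Compound 4 `COc1ccc([C@H]2Oc3cc(OC)c(O)cc3[C@@H]2C)cc1O` has not yet been measured. It differs from compound 1 by hydrogen in place of methyl on an oxygen on an aromatic ring. Because compound 1 already sits at the limit of > 19.4 ug/mL in this assay, at which 1 of the 3 values shown sits, the step is expected to be small or not beyond the scatter, and the estimated step that the limit leaves unreadable from compound 1 to compound 4 from compound 1 to compound 4 carries that expectation. Compound 4 is accordingly expected to give about 25 ug/mL in this assay, within a range from 10 ug/mL to 60 ug/mL, with a real chance that only a limit is reported.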

Compound 4, half-maximal inhibitory concentration: 7.7 ug/mL
Estimate against measurement, compound 4: 3.2-fold (0.51 log units) above, and the stated range ends above it.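

In this assay the series now has its first readable step, an at least 2.5-fold lower number from compound 1 to compound 4 (0.40 log units; beyond the scatter), for hydrogen in place of methyl on an oxygen on an aromatic ring. The true size of this step may be larger, because compound 1 is held only by a limit and not by a number: the limit of > 19.4 ug/mL in this assay, at which 1 of the 4 values shown sits. This oxygen is therefore a position where the change from methoxy to hydroxy moves the reading beyond the scatter, and compound 4 gives the core of compound 1 its first single number, though this direction rests on one pair alone and cannot be called a pattern.

Among these compounds, compound 2 and compound 3 differ from the others in more than one place, so no steps to them can be read, and the same change at the other methoxy groups of the shared core remains open. Also open, going by these compounds, is whether an ethyl group, a longer chain or a carboxylic acid on this oxygen would keep the lower number seen with the hydroxy group of compound 4.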